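The compounds below may be only part of what the source reports. "The series", "measured", "known", "first", "only" and "open" are said of these compounds alone.

Of the compounds shown here, three of a shared core have been measured so far. Compound 1 `Cn1cccc1-c1cc(-c2cccs2)nc(N)c1C#N` gives 45700 nM in a functional assay on SNB-75 cells (Homo sapiens) for inhibition, read by sulforhodamine B assay, with a stated time of 48 h; on this read-out lower numbers stand for stronger inhibition of growth and higher numbers for weaker inhibition of growth. Compound 2 `COc1ccc(-c2cc(-c3cccn3C)c(C#N)c(N)n2)cc1OC` gives 20900 nM in this assay. Compound 3 `Cn1cccc1-c1cc(-c2cccs2)[nH]c(=O)c1C#N` gives 38100 nM in this assay. On these three numbers compound 3 stands second highest: its gap to compound 1 is the smaller one, its gap to compound 2 the larger one, and both gaps lie within the usual scatter of this kind of measurement, so the three compounds cannot be told apart on the numbers shown.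

Compound 4 `Cn1cccc1-c1cc(-c2ccccc2)[nH]c(=O)c1C#N` has not yet been measured. Compared with compound 3 it carries a single change: phenyl in place of thiophen-2-yl on an aromatic carbon. Among the measured compounds shown here, no measured pair in this set shows the effect of this change, so no step for it is available from the data.

On that basis, compound 4 is expected to behave much like compound 3, with a step of a 1.1-fold lower number from compound 3 to compound 4 (0.04 log units; within the scatter) that is expected to stay within the scatter, in no particular direction. Compound 4 is therefore estimated to give about 35000 nM in this assay, with a range from 12000 nM to 100000 nM.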

Compound 4, concentration for 50% growth inhibition: 47400 nM
Compound 4: the middle estimate sits 1.4-fold (0.13 log units) below what was measured, within the range that was stated.
By their numbers in this assay, from the lowest: compounds 2, 3, 1 and 4 (each within the scatter of the next, the first and the last beyond it).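

In this assay, the position next to the ring nitrogen now has its first single-change comparison, phenyl in place of thiophen-2-yl, and it reads a 1.2-fold higher number from compound 3 to compound 4 (0.09 log units; within the scatter). Among the compounds shown here, on this core and this read-out, the six-membered carbon ring and the five-membered sulfur-containing ring therefore cannot be told apart at this carbon, although the step covers only this one pair. Nothing available bears on why the two groups give such similar numbers.

The compounds shown leave open whether an amine, a carboxylic acid or a longer alkyl chain on this same carbon would shift the number beyond the scatter. As far as these compounds go, the 1-methyl-1H-pyrrol-2-yl group and the cyano group are the same in all four compounds, so the effect of replacing either one also remains open.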